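The compounds below may be only part of what the source reports. "The series", "measured", "known", "first", "only" and "open" are said of these compounds alone.

Within the data shown here, compound 2, `CCCn1c(SCc2cc([N+](=O)[O-])ccc2OC)nc2cc(NC(=O)NC(C)(C)C)cc(C(=O)NC)c21`, has the lower of the two numbers measured so far in an assay on isolated protein for inhibition of Gonadotropin-releasing hormone receptor (Rattus norvegicus); on this read-out higher numbers stand for weaker inhibition and lower numbers for stronger inhibition: compound 2 gives 23 nM. Among the measured compounds shown here, its only neighbour in the set is compound 1, `CCCn1c(SCc2cc([N+](=O)[O-])ccc2OC)nc2cc(NC(=O)NC(C)(C)C)ccc21`, which in this assay gives 120 nM. For the measured compounds named here, the one measured step runs between these two: a 5.2-fold lower number from compound 1 to compound 2 (0.72 log units; beyond the scatter).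

Compound 3, `CCCn1c(SCc2cc([N+](=O)[O-])ccc2OC)nc2cc(NC(=O)NC(C)(C)C)cc(C(=O)NC(C)(C)C)c21`, differs from compound 2 in a single place: tert-butyl in place of methyl on an amide-type nitrogen. Going by the values given here, the methylcarbamoyl that enters in the step from compound 1 to compound 2 is the very group that is now enlarged, but no measured pair shows what swapping the methyl on that amide nitrogen for a tert-butyl does. Among the compounds with values here, the only step at hand therefore speaks to the presence of the group, not to its size, and gives no direction for this change. The expectation is that compound 3 stays close to compound 2, with a step of a 1.1-fold higher number from compound 2 to compound 3 (0.04 log units; within the scatter) that is not expected to reach beyond the scatter. Compound 3 is estimated at 25 nM in this assay, with a likely range from 8 nM to 80 nM.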

Compound 3, half-maximal inhibitory concentration: 490 nM
Beside the measured number, compound 3's estimate is 20-fold (1.29 log units) below it; measured number outside the range, above it.
By their numbers in this assay, from the lowest: compound 2; then compound 1; then compound 3.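

The group on this amide nitrogen matters a great deal in this assay: tert-butyl in place of methyl gives a 21-fold higher number from compound 2 to compound 3 (1.33 log units; beyond the scatter). The carbamoyl group alone therefore does not bring the lower number, as the (tert-butyl)carbamoyl in place of hydrogen on the aromatic carbon gives a 4.1-fold higher number from compound 1 to compound 3 (0.61 log units; beyond the scatter), the opposite direction to a 5.2-fold lower number from compound 1 to compound 2 (0.72 log units; beyond the scatter), so the same position can move the number either way depending on what the amide nitrogen carries. Nothing available explains why methyl and tert-butyl part ways so sharply here.

As far as these compounds go, three compounds give only two end points on this nitrogen, so it remains open where between methyl and tert-butyl the number begins to climb, and whether an ethyl or an isopropyl group would behave like methyl or like tert-butyl. From the compounds shown here alone, it also remains open whether methyl is needed at all, which a primary carboxamide with two hydrogens on its nitrogen could answer, and whether a carboxylic acid at this aromatic carbon would keep the lower number.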